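A few compounds are considered here, and "the series" means these few. Any claim that something is new, unique, unknown or untested is made for them only; others in the source may bear on it.

Compound 1, `C=CC1=C(C(=O)NCc2ccc(Cl)cc2)C(c2ccc(F)cc2)OC1`, is the starting point. In a functional assay on HeLa cells (Homo sapiens) for cytotoxicity, read by MTT assay, with a stated time of 24 h (a lower number here means a stronger inhibitor, a higher number a weaker inhibitor), compound 1 gives > 100000 nM, which is a limit of the assay rather than a measured number. Two related compounds share the same core. Compound 2, `C=CC1=C(C(=O)Nc2ccccc2)C(c2ccc(F)cc2)OC1`, gives > 100000 nM in this assay, again a limit. Compound 3, `C=CC1=C(C(=O)NCCCCC)C(c2ccc(F)cc2)OC1`, gives > 100000 nM in this assay, also a limit. The changes among these three are therefore unreadable in size: a step that the two limits leave unreadable from compound 1 to compound 2, a step that the two limits leave unreadable from compound 1 to compound 3 and a step that the two limits leave unreadable from compound 2 to compound 3 all sit at the limit of > 100000 nM in this assay, at which 3 of the 3 values shown sit, so no step on the amide side shows any effect that can be measured. The new compound 4, `C=CC1=C(C(=O)NCc2ccc(Cl)cc2)C(c2ccc(OC)cc2)OC1`, changes a different part of the structure: methoxy in place of fluoro on an aromatic carbon. Among the compounds with values here, no measured step touches this aromatic ring, so nothing among the three compounds points toward a stronger or weaker inhibitor. Compound 4 is expected to stay at the same limit, an estimate of 150000 nM with a range from 50000 nM to 500000 nM. For compound 4 the expected change, a step that the limit leaves unreadable from compound 1 to compound 4, is an estimate of essentially no readable shift.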

Compound 4, half-maximal inhibitory concentration: > 100000 nM
Compound 4: only a limit was reported; the forecaster's own chance of this, stated with the estimate: 85%; the middle value is on the limit's open side.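

Compound 1 and compound 4 both end at a limit of the assay rather than a measured number, so the size of the step from fluoro to methoxy cannot be read: the limit of > 100000 nM in this assay, at which 4 of the 4 values shown sit. The compounds shown leave open which structural change, if any, would give a measurable value in this assay.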